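A Hydroxy Added on the Side Chain of Compound 1

The compounds below may be only part of what the source reports. "The series", "measured", "known", "first", "only" and "open" are said of these compounds alone.

Compound 1 `CCNC(=O)c1cc(C(=O)NC)c(=O)n(Cc2ccccc2)c1`: in a physicochemical assay for solubility (a higher number here means a more soluble compound, a lower number a less soluble compound), compound 1 gives >= 144 ug/mL, which is a limit of the assay.
Compound 2 `CNC(=O)c1cc(C(=O)NC2CC2)cn(Cc2cccc([C@@H](C)O)c2)c1=O`: compound 2 gives >= 131 ug/mL, also a limit.
Compound 3 `CNC(=O)c1cc(C(=O)NC2CC2)cn(Cc2cccc3cn[nH]c23)c1=O`: compound 3 gives >= 181 ug/mL, again a limit.

Compound 1 thus stands at a limit rather than a number, and the other two values shown are limits as well, among them (the limit of >= 181 ug/mL in this assay, at which 1 of the 3 values shown sits). Among the compounds with values here, the only measured step, a step that the two limits leave unreadable from compound 2 to compound 3, is unreadable, both of its ends being limits, so no measured step gives a readable size to lean on.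

Compound 4 `CNC(=O)c1cc(C(=O)NCCO)cn(Cc2ccccc2)c1=O` differs from compound 1 by hydroxy in place of hydrogen on a saturated chain carbon, two bonds along the chain from an amide-type nitrogen. Nothing measured bears directly on this change. Compound 4 is therefore expected at 160 ug/mL, from 100 ug/mL to 260 ug/mL. The expected step that the limit leaves unreadable from compound 1 to compound 4 is none beyond the scatter, and a limit is again likely.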

Compound 4, solubility: >= 140 ug/mL
Compound 4: only a limit was reported; the forecaster's own chance of this, stated with the estimate: 70%; the middle value is on the limit's open side.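

In this assay compound 1 and compound 4 both stand at limits, and the step between them cannot be read. The compounds shown leave open the true value of each compound and the size of the change from hydrogen to hydroxy.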